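Chain extension of a hydroxamate HDAC6 inhibitor series

The source may hold more compounds than are shown below. What is called first, only, known or untested is meant among the compounds shown, and "the series" means these compounds.

Measured so far: compound 1 `CS(=O)(=O)c1ccc(-n2ccc3cnc(Nc4cnn(CCCCCCC(=O)NO)c4)nc32)cc1` with 5.9 nM in an assay on isolated protein for inhibition of protein deacetylase HDAC6 (Homo sapiens), with a stated time of 60 min; on this read-out higher numbers stand for weaker inhibition and lower numbers for stronger inhibition; compound 2 `O=C(CCCCCCn1cc(Nc2ncc3ccn(Cc4ccccc4F)c3n2)cn1)NO` with 8.4 nM; compound 3 `O=C(CCCCCn1cc(Nc2ncc3ccn(Cc4cccc(Cl)c4)c3n2)cn1)NO` with 34.4 nM.

Compound 3 has the highest number of the three in this assay; compound 2 is nearest, compound 1 furthest. Compound 4 `O=C(CCCCCCn1cc(Nc2ncc3ccn(Cc4cccc(Cl)c4)c3n2)cn1)NO` differs from compound 3 by (hydroxycarbamoyl)methyl in place of hydroxycarbamoyl on a saturated chain carbon, five bonds along the chain from an aromatic nitrogen. Among the measured compounds shown here, the one step measured so far, a 1.4-fold higher number from compound 1 to compound 2 (0.15 log units; within the scatter), changes the aryl group, not the chain, so it does not bear on this change. Compound 1 and compound 2 share the longer chain present in compound 4 and give lower numbers than compound 3. Compound 4 is therefore expected to show a lower number, estimated at 10 nM (range 4 nM to 25 nM), a step of a 3.4-fold lower number from compound 3 to compound 4 (0.54 log units; beyond the scatter).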

Compound 4, half-maximal inhibitory concentration: 36.8 nM
Estimate against measurement, compound 4: 3.7-fold (0.57 log units) below; the whole stated range lies below it.
By their numbers in this assay, from the lowest: compounds 1 and 2 (each within the scatter of the next); then compounds 3 and 4 (each within the scatter of the next).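

In this assay, (hydroxycarbamoyl)methyl in place of hydroxycarbamoyl at this chain position gives a 1.1-fold higher number from compound 3 to compound 4 (0.03 log units; within the scatter), so with the 3-chlorobenzyl group the two chain lengths cannot be told apart. On the longer chain, the aryl group does matter: 3-chlorophenyl in place of 2-fluorophenyl gives a 4.4-fold higher number from compound 2 to compound 4 (0.64 log units; beyond the scatter), and 3-chlorobenzyl in place of 4-(methylsulfonyl)phenyl gives a 6.2-fold higher number from compound 1 to compound 4 (0.79 log units; beyond the scatter). Nothing available accounts for these results.

From the compounds shown here alone, it remains open whether chain length would matter with a 2-fluorobenzyl group. Also open, going by these compounds, is how a still longer chain, or a carboxylic acid in place of hydroxycarbamoyl, would read.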